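A Phenyl Group Gives Way to Hydrogen

A few compounds are considered here, and "the series" means these few. Any claim that something is new, unique, unknown or untested is made for them only; others in the source may bear on it.

Two compounds with a shared core have numbers in a functional assay on Raji cells (Homo sapiens) for cytotoxicity, read by CCK-8 assay, with a stated time of 24 h; on this read-out higher numbers stand for weaker inhibition and lower numbers for stronger inhibition. Compound 1 (`C=CC(=O)N1C(=O)CC(c2ccccc2Cl)Sc2ccccc21`) gives 50400 nM, and compound 2 (`C=CC(=O)N1C(=O)CC(c2ccc(-c3ccccc3)cc2)Sc2ccccc21`) gives 56300 nM. These two numbers lie within the usual scatter of repeated measurements, so compound 2 stands level with compound 1 and neither can be ranked above the other.

Compound 3 (`C=CC(=O)N1C(=O)CC(c2ccccc2)Sc2ccccc21`) has not yet been measured. It comes from compound 2 through a single change: hydrogen in place of phenyl on an aromatic carbon. Put simply, hydrogen stands in place of phenyl on an aromatic carbon, para to a large group.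

For the measured compounds named here, no measured pair shows a change of this kind, so the data give no direct guide to its effect. Going by the values given here, the only hint is that compound 2, at 56300 nM, sits level with compound 1, at 50400 nM. A small change is therefore expected in this assay: the estimated 1.3-fold lower number from compound 2 to compound 3 (0.10 log units; within the scatter) stays within the scatter, leaning only slightly towards a lower number. Compound 3 is expected at about 45000 nM, with an estimated range from 18000 nM to 100000 nM.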

Compound 3, half-maximal inhibitory concentration: 74100 nM
Estimate against measurement, compound 3: 1.6-fold (0.22 log units) below, and the stated range covers the measured number.
By their numbers in this assay, from the lowest: compounds 1, 2 and 3 (each within the scatter of the next).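

Taking the phenyl group away and leaving a hydrogen atom on the aromatic carbon gives a 1.3-fold higher number from compound 2 to compound 3 (0.12 log units; within the scatter) in this assay. Even the loss of a whole six-membered aromatic ring therefore makes no readable difference to the number at this position, and compound 3 stands level with compound 2. Hydrogen in place of chloro on an aromatic carbon gives a 1.5-fold higher number from compound 1 to compound 3 (0.17 log units; within the scatter), so neither chloro nor phenyl can be told apart from plain hydrogen on this ring, and the data shown offer no explanation for this flat picture.

The compounds shown carry only chloro, phenyl or hydrogen on this ring, so it remains open whether a group of a different kind, such as an amine or a carboxylic acid, would move the number beyond the scatter. From the compounds shown here alone, it also remains open whether a change elsewhere on the shared core would matter more in this assay, since all three compounds differ only on this one ring.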